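The source may hold more compounds than are shown below. What is called first, only, known or untested is meant among the compounds shown, and "the series" means these compounds.

Working notes on the series, all read in a functional assay on LOX cells (Homo sapiens) for antiproliferative activity, read by WST assay, with a stated time of 3 days; a lower number here means a stronger inhibitor, a higher number a weaker inhibitor. Compound 1 `O=c1[nH]c(=O)n([C@@H]2O[C@H](CO)[C@@H](O)[C@H]2O)c(I)c1F`, with iodo on the shared core, reports only a limit, > 50000 nM. Compound 2 `[N-]=[N+]=Nc1c(F)c(=O)[nH]c(=O)n1[C@@H]1O[C@H](CO)[C@@H](O)[C@H]1O`, with azido, gives 2300 nM, and compound 3 `CCc1c(F)c(=O)[nH]c(=O)n1[C@@H]1O[C@H](CO)[C@@H](O)[C@H]1O`, with ethyl, gives 4500 nM. These last two stand level: a 2.0-fold higher number from compound 2 to compound 3 (0.29 log units; within the scatter) lies within the scatter.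

Next comes compound 4 `O=Cc1c(F)c(=O)[nH]c(=O)n1[C@@H]1O[C@H](CO)[C@@H](O)[C@H]1O`, reached from compound 3 by one change: formyl in place of ethyl on an aromatic carbon.

Within the data shown here, no measured step involves formyl, so the bearing is indirect. Two large steps beyond the scatter leave compound 1: an at least 21-fold lower number from compound 1 to compound 2 (1.33 log units; beyond the scatter) and an at least 11-fold lower number from compound 1 to compound 3 (1.04 log units; beyond the scatter). These show that the group at this place can matter a great deal in this assay. Among the measured compounds shown here, the only step between two measured numbers, the one from azido to ethyl, stays within the scatter. Compound 2 and compound 3 therefore suggest tolerance, while compound 1 warns that a replacement can lose nearly all measurable activity. The data give no firm direction, so a small move towards a higher number is expected, with a wide margin on that side. The estimated step is a 1.6-fold higher number from compound 3 to compound 4 (0.19 log units; within the scatter). For compound 4 the estimated value is 7000 nM, with an expected range of 1500 nM to 45000 nM.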

Compound 4, half-maximal inhibitory concentration: 400 nM
The estimate for compound 4 lay 18-fold (1.24 log units) above the measured number, outside the stated range (below it).
By their numbers in this assay, from the lowest: compound 4; then compounds 2 and 3 (each within the scatter of the next). At a limit, above all of these: compound 1.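

In this assay, the formyl group separates itself from the other measured groups on this aromatic carbon next to the ring nitrogen, with an 11-fold lower number from compound 3 to compound 4 (1.05 log units; beyond the scatter) and a 5.8-fold lower number from compound 2 to compound 4 (0.76 log units; beyond the scatter), so this place now shows a spread among measured numbers and not only against a limit. Ethyl and formyl carry the same count of heavy atoms, so that count alone does not track the step; the change swaps a carbon for an oxygen and brings in a double bond outside the aromatic ring and a hydrogen-bond acceptor, though the series cannot say which of these matters. The widest step, an at least 120-fold lower number from compound 1 to compound 4 (2.09 log units; beyond the scatter), is only a bound, as compound 1 reports a limit of the assay: the limit of > 50000 nM in this assay, at which 1 of the 4 values shown sits.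

On these data alone, whether a carboxylic acid, an amide or a hydroxymethyl group at this place would keep the low number of compound 4 stays open, and so does how a longer chain would compare with ethyl. The compounds shown also leave open whether the step from ethyl to formyl holds in cell lines other than this one.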